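The source may report more compounds than this note shows. Statements on the series, on what has been measured and on what is new or still open speak of the compounds shown alone.

Measured so far:
Compound 1 `CC(C)=CC(=O)Nc1c(C(O)(C(F)(F)F)C(F)(F)F)ccc2ccccc12`: 46 nM
Compound 2 `O=C(Nc1c(C(O)(C(F)(F)F)C(F)(F)F)ccc2ccccc12)C1CCCC1`: 495 nM

Going by the values given here, compound 2 has the higher of the two numbers in an assay on LtK cells with ATP-sensitive inward rectifier potassium channel 11 (Homo sapiens) as the target; a lower number here means that less compound is needed, a higher number that more compound is needed for the effect; its only neighbour is compound 1, and the step of an 11-fold higher number from compound 1 to compound 2 (1.03 log units; beyond the scatter) was large. Compound 3 `O=C(Nc1c(C(O)(C(F)(F)F)C(F)(F)F)ccc2ccccc12)c1ccccc1` differs from compound 2 by phenyl in place of cyclopentyl on a carbonyl carbon. Among the compounds with values here, no measured step swaps one ring for another at this place, so the single step that bears on it shows only that what sits on this carbonyl carbon moves this assay strongly. The expected step of a 2.0-fold lower number from compound 2 to compound 3 (0.30 log units; within the scatter) is therefore modest and uncertain in direction. Compound 3 is estimated at 250 nM, within 50 nM to 1200 nM.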

Compound 3, half-maximal effective concentration: 44 nM
The estimate for compound 3 lay 5.7-fold (0.75 log units) above the measured number, and the stated range ends above it.
By their numbers in this assay, from the lowest: compounds 3 and 1 (each within the scatter of the next); then compound 2.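

In this assay the kind of ring on this carbonyl carbon matters, not just the presence of a ring: phenyl in place of cyclopentyl gives a large step (an 11-fold lower number from compound 2 to compound 3 (1.05 log units; beyond the scatter)). Phenyl and the open-chain 2-methylprop-1-en-1-yl group read alike within the scatter (a 1.0-fold lower number from compound 1 to compound 3 (0.02 log units; within the scatter)), so among these three compounds only cyclopentyl carries the higher number. No measurement available here explains this difference.

Still open, as far as these compounds go, is how a saturated six-membered cyclohexyl ring would read at this place. From the compounds shown here alone, an amine or a longer chain there is equally open.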